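A New Group on a Carbonyl Carbon, Tested at the Limit

The source may report more compounds than this note shows. Statements on the series, on what has been measured and on what is new or still open speak of the compounds shown alone.

In a functional assay on NCI-H460 cells (Homo sapiens) for cytotoxicity, read by MTT assay, with a stated time of 48 h (a higher number here means a weaker inhibitor, a lower number a stronger inhibitor), compound 1 `C=C1C(=O)O[C@H]2CC3=C[C@H](C/C(C)=C/[C@@H](OC(=O)c4ccc(C(F)(F)F)cc4)[C@H]12)OC3=O` gives > 10000 nM, which is a limit and not a number. Compound 2 `C=C1C(=O)O[C@H]2CC3=C[C@H](C/C(C)=C/[C@@H](OC(=O)C4CCC(F)(F)CC4)[C@H]12)OC3=O` gives > 10000 nM, which is also a limit, so it has no exact place on the scale. Within the data shown here, the only measured step is a step that the two limits leave unreadable from compound 1 to compound 2. Among the measured compounds shown here, the sole evidence for what follows is the limit of > 10000 nM in this assay, at which 2 of the 2 values shown sit.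

Compound 3 `C=C1C(=O)O[C@H]2CC3=C[C@H](C/C(C)=C/[C@@H](OC(=O)C45CCC(C)(C(=O)O4)C5(C)C)[C@H]12)OC3=O` keeps the shared core and changes one group on a carbonyl carbon: a group of 11 heavy atoms (9 carbon, 2 oxygen; one five-membered non-aromatic ring of carbon only, one five-membered non-aromatic ring with 1 hetero atom) in place of a group of 8 heavy atoms (6 carbon, 2 fluorine; one six-membered non-aromatic ring of carbon only), on a carbonyl carbon. For the measured compounds named here, no measured step has a readable size, so the data give no direction for this change, and no clear step is expected. The expected change is a step that the limit leaves unreadable from compound 2 to compound 3, an estimate resting on very little. Compound 3 may well report only a limit too. Compound 3 is estimated at 12000 nM, with an expected range from 4000 nM to 30000 nM.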

Compound 3, half-maximal inhibitory concentration: 2000 nM
Estimate against measurement, compound 3: 6.0-fold (0.78 log units) above, and the stated range ends above it.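

Among these compounds, compound 3 is the only one of the three compounds with a read-out that is a number and not a limit, so this position on a carbonyl carbon can move the result once the right group sits there. In this assay the new group gives an at least 5.0-fold lower number from compound 2 to compound 3 (0.69 log units; beyond the scatter), and against the aromatic group it gives an at least 5.0-fold lower number from compound 1 to compound 3 (0.69 log units; beyond the scatter). Both sizes are minimums, as the two starting compounds stand at a limit and their true values could lie further away: the limit of > 10000 nM in this assay, at which 2 of the 3 values shown sit.

Which part of the entering group carries this step stays open, the five-membered ring with 1 hetero atom or the five-membered ring of carbon only. How an amine or a carboxylic acid on this carbonyl carbon would read is also unknown.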